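The compounds below may be only part of what the source reports. "The series", "measured", "known", "first", "only" and "open" are said of these compounds alone.

Two compounds measured in a functional assay, read by spectrophotometry, with a stated time of 15 min, tested at 60 ug/mL (on this read-out higher numbers stand for a stronger effect at the one concentration tested and lower numbers for a weaker effect), are known. Compound 1 `COC(=O)c1cc(-c2csc(N/N=C/c3ccc(Cl)cc3Cl)n2)ccc1OCc1ccccc1` gives 41.9% in this assay. For the measured compounds named here, compound 2 `Cc1ccc(-c2csc(N/N=C/c3cccs3)n2)cc1` gives 97.6% in this assay, the higher of the two numbers; the only other number, that of compound 1, lies far below it, beyond the scatter. Compound 3 `Fc1ccc(-c2csc(N/N=C/c3cccs3)n2)cc1` has not been measured. Compound 3 differs from compound 2 by fluoro in place of methyl on an aromatic carbon. Going by the values given here, no step between measured compounds shows what such a change does here. A small fall, or none beyond the scatter, is expected, and the step in this assay is estimated at a number 12.6 percentage points lower from compound 2 to compound 3 (beyond the scatter). Compound 3 is expected to give about 85%, within 55% to 99%.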

Compound 3, a percentage reported as inhibition, at one concentration (the size of the read-out at that concentration, not a potency): 94.6%
Beside the measured number, compound 3's estimate is 9.6 percentage points below it, and the stated range covers the measured number.
By their numbers in this assay, from the lowest: compound 1; then compounds 3 and 2 (each within the scatter of the next).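

In this assay, the step for fluoro in place of methyl on an aromatic carbon, para to a large group, is a number 3 percentage points lower from compound 2 to compound 3 (within the scatter). For the compounds shown here, this is the first step read at this position, and it shows that the two groups cannot be told apart here at the one concentration tested. Nothing measured offers a reason for this result. The compounds shown leave open whether an amine or a carboxylic acid at this position would give a similar reading. From the compounds shown here alone, whether the same change would read alike on the core of compound 1 also stays open.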